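The source may hold more compounds than are shown below. What is called first, only, known or untested is meant among the compounds shown, and "the series" means these compounds.

Measured compounds:
compound 1 `CCOC(=O)c1cc([Se]Cc2ccccc2)c2cc(OC)ccc2n1` — 40700 nM
compound 2 `CCOC(=O)c1cc([Se]c2ccc3cc(OC)ccc3c2)c2cc(OC)ccc2n1` — 30800 nM
compound 3 `CCOC(=O)c1cc([Se]Cc2ccccc2)c2cc(Cl)ccc2n1` — 84500 nM

All three were tested in a functional assay on SK-MEL-147 cells (Homo sapiens) for cytotoxicity, read by MTT assay, with a stated time of 24 h; a higher number here means that more compound is needed for the effect, a lower number that less compound is needed. Compound 1 and compound 2 share a core but differ by a large part of the molecule; the difference between the two cores is not broken down here, and their two numbers lie within the scatter of each other. Compound 3 is the partner of compound 1: it differs by chloro in place of methoxy on an aromatic carbon, and that single change gave a 2.1-fold higher number from compound 1 to compound 3 (0.32 log units; beyond the scatter).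

Compound 4 `CCOC(=O)c1cc([Se]c2ccc3cc(OC)ccc3c2)c2cc(Cl)ccc2n1` has not yet been measured. It stands to compound 2 as compound 3 stands to compound 1, differing by chloro in place of methoxy on an aromatic carbon. The surroundings of the changed atom are described in the same words in both pairs, so this is the same change, seen once so far.

Because the change from compound 1 to compound 3 gave a 2.1-fold higher number from compound 1 to compound 3 (0.32 log units; beyond the scatter), a step of similar size is expected here: the estimated step is a 2.1-fold higher number from compound 2 to compound 4 (0.32 log units; beyond the scatter). With that, compound 4 is expected to give about 65000 nM in this assay, most likely between 30000 nM and 140000 nM.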

Compound 4, half-maximal effective concentration: 16200 nM
Beside the measured number, compound 4's estimate is 4.0-fold (0.60 log units) above it; the measured number lies below the stated range.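

In this assay, chloro in place of methoxy on an aromatic carbon gave a 1.9-fold lower number from compound 2 to compound 4 (0.28 log units; within the scatter), a step too small to count as a real change on its own. Set beside the earlier step, the same swap did not carry over from one core to the other: the same change on two cores in this assay, a 2.1-fold higher number (0.32 log units; beyond the scatter) from compound 1 to compound 3 and a 1.9-fold lower number (0.28 log units; within the scatter) from compound 2 to compound 4, 3.9-fold (0.60 log units) apart, beyond the scatter of two such steps. Within the data shown here, this shows that the step seen on the core of compound 1 is not a safe guide to the core of compound 2, but with only one pair on each core it does not show why the two differ or what the swap would do on a further core.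

The compounds shown leave open how other groups on this aromatic carbon, such as fluoro, bromo or an amine, would behave on either core. They also leave open what part the ethyl ester plays, which a carboxylic acid or an amide in its place could test.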